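A few compounds are considered here, and "the series" means these few. Any claim that something is new, unique, unknown or untested is made for them only; others in the source may bear on it.

In a functional assay on HCT-15 cells (Homo sapiens) for cytotoxicity, read by sulforhodamine B assay, with a stated time of 72 h (on this read-out lower numbers stand for stronger inhibition of growth and higher numbers for weaker inhibition of growth), compound 2 `O=C(Nc1ccc(O)cc1)C1CCc2ccccc2N1` gives > 100000 nM, which is a limit of the assay and not a number. Compound 1 `O=C(Nc1ccc(C(F)(F)F)cc1)C1CCc2ccccc2N1` gives 17600 nM. Among the measured compounds shown here, the one measured step, an at least 5.6-fold higher number from compound 1 to compound 2 (0.75 log units; beyond the scatter), puts hydroxy in place of trifluoromethyl. Compound 3 `COc1ccc(NC(=O)C2CCc3ccccc3N2)cc1` carries methyl in place of hydrogen on an oxygen on an aromatic ring, hydroxy to methoxy: methyl in place of hydrogen on an oxygen on an aromatic ring. That measured step bears only indirectly, since it shows that compound 1, without hydroxy, reads 17600 nM. A modest move toward lower numbers is therefore expected, an estimated at least 2.0-fold lower number from compound 2 to compound 3 (0.30 log units; that floor lies within the scatter). For compound 3 the estimate is 50000 nM, with an expected range from 25000 nM to 100000 nM.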

Compound 3, concentration for 50% growth inhibition: 50200 nM
Compound 3: the middle estimate sits 1.0-fold (0.00 log units) below what was measured, within the range that was stated.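

Methyl in place of hydrogen on the oxygen gives an at least 1.9-fold lower number from compound 2 to compound 3 (0.29 log units; that floor lies within the scatter) and so proves only a floor that lies inside the usual scatter. From the compounds shown here alone, compound 2 stands at a limit of the assay and not a number, so the true size of that step stays unknown: the limit of > 100000 nM in this assay, at which 1 of the 3 values shown sits. The firmer comparison is with trifluoromethyl, where methoxy gives a 2.9-fold higher number from compound 1 to compound 3 (0.46 log units; beyond the scatter) and so, unlike hydroxy, yields a measured number on this aromatic carbon.

Going by these compounds, whether an amine, a carboxylic acid or a longer chain such as ethoxy on this carbon would read closer to compound 1 or compound 3 stays open. So does how far compound 2 truly lies from the others.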